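The compounds below may be only part of what the source reports. "The series", "measured", "known", "first", "only" and "open" are said of these compounds alone.

Measured compounds:
compound 1, `CSc1cnc2ccccc2c1[Se]CC#CCO`: 3.4 ug/mL
compound 2, `CCOC(=O)OCC#CCSc1c(SC)cnc2ccccc12`: 33.1 ug/mL
compound 3, `C#CCSc1cnc2ccccc2c1SCC#CCCl`: 12.9 ug/mL

In a functional assay on SW707 cells (Homo sapiens) for antiproliferative activity, with a stated time of 72 h (on this read-out lower numbers stand for stronger inhibition and higher numbers for weaker inhibition), compound 3 stands second highest of the three numbers; compound 2 gives a higher number beyond the usual scatter, and compound 1 lies further away with a lower number, also beyond the scatter. Compound 4, `CSc1cnc2ccccc2c1SCC#CCCl`, has not yet been measured. It differs from compound 3 in one place: hydrogen in place of ethynyl on a saturated chain carbon bound to a sulfur. Cut one bond further out, the change reads propargyl to methyl, so propargylsulfanyl becomes methylsulfanyl. Going by the values given here, no measured pair isolates this change, so the step is uncertain. Compound 1 and compound 2 both carry methylsulfanyl and give numbers on either side of compound 3, offering no clear direction. A modest rise in number toward weaker inhibition is expected, with the estimated step of a 1.2-fold higher number from compound 3 to compound 4 (0.09 log units; within the scatter). Compound 4 is thus expected to give about 16 ug/mL, within 6 ug/mL to 40 ug/mL.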

Compound 4, concentration for 50% inhibition: 3.7 ug/mL
Beside the measured number, compound 4's estimate is 4.3-fold (0.64 log units) above it, outside the stated range (below it).
By their numbers in this assay, from the lowest: compounds 1 and 4 (each within the scatter of the next); then compound 3; then compound 2.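

In this assay, methylsulfanyl in place of propargylsulfanyl gives a 3.5-fold lower number from compound 3 to compound 4 (0.54 log units; beyond the scatter), so this position responds to the change and the loss of ethynyl goes with stronger inhibition. Chloro in place of (ethoxycarbonyl)oxy on a saturated chain carbon bound to a triple-bonded carbon gives an 8.9-fold lower number from compound 2 to compound 4 (0.95 log units; beyond the scatter), whereas the exchange of a sulfur and chlorine group for a selenium and oxygen group on an aromatic carbon gives a 1.1-fold higher number from compound 1 to compound 4 (0.04 log units; within the scatter), which lies within the usual scatter. No measurement here explains these differences. Going by these compounds, whether an ethyl group or a longer chain in place of propargyl would keep the lower number remains open.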